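Two Limit Values and a Methylpiperazine Replacement

The source may report more compounds than this note shows. Statements on the series, on what has been measured and on what is new or still open speak of the compounds shown alone.

compound 1 `CS(=O)(=O)c1ccc(C(=O)N2CCC(C(=O)N3CCc4ccccc43)CC2)cc1[N+](=O)[O-]`: > 60000 nM
compound 2 `CN(Cc1ccccc1F)C(=O)C1CCN(C(=O)c2ccc(S(C)(=O)=O)c([N+](=O)[O-])c2)CC1`: > 60000 nM

In an assay on isolated protein for inhibition of thyroid hormone receptor beta (Homo sapiens), read by fluorescence polarization (a higher number here means a weaker inhibitor, a lower number a stronger inhibitor), compound 1 reaches only a limit of the assay, > 60000 nM. Compound 2 likewise gives only a limit in this assay, > 60000 nM. The step that the two limits leave unreadable from compound 1 to compound 2 therefore cannot be sized, and compound 2 stands at the limit rather than at a number. Compound 3 `CN1CCN(C(=O)C2CCN(C(=O)c3ccc(S(C)(=O)=O)c([N+](=O)[O-])c3)CC2)CC1` differs from compound 2 by 4-methylpiperazin-1-yl in place of (2-fluorobenzyl)(methyl)amino on a carbonyl carbon. Among the measured compounds shown here, the one measured step bears on the same carbonyl carbon, yet its size is hidden by the two limits, so neither a direction nor a magnitude can be read from it. Because both measured values sit at the limit of > 60000 nM in this assay, at which 2 of the 2 values shown sit, compound 3 is expected to remain at the limit as well, and the step of a number no higher from compound 2 to compound 3 (the limit leaves the size open) is estimated to be none beyond the scatter. Compound 3 is accordingly estimated at 60000 nM, with a range from 20000 nM to 200000 nM.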

Compound 3, half-maximal inhibitory concentration: > 60000 nM
Compound 3 gave a limit, no number; the forecaster's own chance of this, stated with the estimate: 85%; the middle value sits exactly at the limit.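

Compound 3 gives only a limit in this assay, > 60000 nM. Among the compounds shown here, no step among compound 1, compound 2 and compound 3 can be read from these limits. The compounds shown leave open whether any group on this carbonyl carbon would give a measurable value.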